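Swapping a Tetrazole for an Imidazole on the Shared Core

A few compounds are considered here, and "the series" means these few. Any claim that something is new, unique, unknown or untested is made for them only; others in the source may bear on it.

Among the compounds with values here, the three compounds measured so far share a core and were all tested in a functional assay on a cell-free system (plasma) with sterol O-acyltransferase, Soat (Rattus norvegicus) as the target; a lower number here means that less compound is needed, a higher number that more compound is needed for the effect. Compound 1 `Cc1cc(C)c(NC(=O)N(Cc2cccc(-c3nnn(C)n3)c2)C2CCCCCC2)c(C)c1` gives in this assay only the limit < 1 mg/kg, so no exact number is known for it. Compound 2 `CN(C)c1ccc(CN(Cc2cccc(-c3cc[nH]n3)c2)C(=O)Nc2c(F)cc(F)cc2F)cc1` likewise gives only a limit in this assay, namely < 0.32 mg/kg. Compound 3 `CSc1cc(C)nc(SC)c1NC(=O)N(Cc1ccccc1)Cc1cccc(-c2ccnn2C)c1` gives the limit < 1 mg/kg in this assay. Compound 1 thus stands at a limit shared with one other compound, as the limit of < 1 mg/kg in this assay, at which 2 of the 3 values shown sit, shows, while the limit of < 0.32 mg/kg in this assay, at which 1 of the 3 values shown sits, marks where compound 2 sits. Within the data shown here, all three values are limits, so no measured step between any pair can be stated, and their order cannot be read from the numbers.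

Compound 4 `Cc1cc(C)c(NC(=O)N(Cc2cccc(-c3c[nH]cn3)c2)C2CCCCCC2)c(C)c1` differs from compound 1 in one place: 1H-imidazol-4-yl in place of 2-methyl-2H-tetrazol-5-yl on an aromatic carbon. Among the measured compounds shown here, with no measured step to lean on, the expectation for this change is no move beyond the scatter in this assay, in either direction. The expected step from compound 1 to compound 4 is a step that the limit leaves unreadable from compound 1 to compound 4. For compound 4 the estimated value in this assay is 0.5 mg/kg, with a range from 0.1 mg/kg to 3 mg/kg, and it is quite possible that this assay again reports only a limit for compound 4.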

Compound 4, dose for half-maximal effect: < 1 mg/kg
Compound 4 gave a limit, no number; the forecaster's own chance of this, stated with the estimate: 65%; the middle value does not contradict the limit.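

Compound 4 gives < 1 mg/kg in this assay, which is a limit and not a number. Compound 1 also stands at a limit, so no step can be read from compound 1 to compound 4. On these data alone, whether 1H-imidazol-4-yl in place of 2-methyl-2H-tetrazol-5-yl changes the dose needed, and in which direction, stays open, as do the exact values of all four compounds.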